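Hydroxy for trifluoromethyl across two related cores

A few compounds are considered here, and "the series" means these few. Any claim that something is new, unique, unknown or untested is made for them only; others in the source may bear on it.

Of the compounds shown here, three have been measured in an assay on cells for inhibition of Voltage-dependent T-type calcium channel subunit alpha-1H (Homo sapiens), read by FLIPR and calcium flux, with stated times of 600 s and 300 s; on this read-out lower numbers stand for stronger inhibition and higher numbers for weaker inhibition. Compound 1, `CN(Cc1ccc(OCCCNC(=N)N)cc1)c1nc2ccc(Oc3ccc(C(F)(F)F)cc3)cc2s1`, gives 212000 nM in this assay. Compound 2, `CN(Cc1ccc(OCCCNC(=N)N)cc1)c1nc2ccc(Oc3ccc(O)cc3)cc2s1`, gives 332000 nM. Compound 3, `N=C(N)NCCCOc1ccc(CNc2nc3ccc(Oc4ccc(C(F)(F)F)cc4)cc3s2)cc1`, gives 195000 nM, and compound 4, `N=C(N)NCCCOc1ccc(CNc2nc3ccc(Oc4ccc(O)cc4)cc3s2)cc1`, is not yet measured.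

The core of compound 1 and the core of compound 3 differ by hydrogen in place of methyl on a nitrogen on an aromatic ring. The step between them in this assay is a 1.1-fold lower number from compound 1 to compound 3 (0.04 log units; within the scatter), so the two cores read as equivalent within the present data.

Compound 2 differs from compound 1 by hydroxy in place of trifluoromethyl on an aromatic carbon. The step in this assay is a 1.6-fold higher number from compound 1 to compound 2 (0.19 log units; within the scatter). Compound 4 differs from compound 3 by hydroxy in place of trifluoromethyl on an aromatic carbon; the place is described in the same words for both pairs, on an aromatic carbon of a six-membered aromatic ring of carbon only, para to a large group, so this is the same change made a second time, here on the core of compound 3.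

Given that the change from compound 1 to compound 2 stayed within the scatter, and that compound 3 with 195000 nM sits close to compound 1, the expectation for compound 4 in this assay is a step of about a 1.6-fold higher number from compound 3 to compound 4 (0.20 log units; within the scatter), which would also stay within the scatter. Compound 4 is therefore estimated at 310000 nM, with a range from 150000 nM to 650000 nM, resting on the step of a 1.6-fold higher number from compound 1 to compound 2 (0.19 log units; within the scatter) applied to the value of compound 3.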

Compound 4, half-maximal inhibitory concentration: 319000 nM
Compound 4: middle estimate off by 1.0-fold (0.01 log units), on the low side; measured number inside the range.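

In this assay, hydroxy in place of trifluoromethyl on the core of compound 3 gives a 1.6-fold higher number from compound 3 to compound 4 (0.21 log units; within the scatter), and this step agrees with the one seen for the same change on the core of compound 1: the same change on two cores in this assay, a 1.6-fold higher number (0.19 log units; within the scatter) from compound 1 to compound 2 and a 1.6-fold higher number (0.21 log units; within the scatter) from compound 3 to compound 4, 1.0-fold (0.02 log units) apart, within the scatter of two such steps. The hydrogen in place of methyl on the nitrogen also reads the same with hydroxy as with trifluoromethyl on the ring, the new step being a 1.0-fold lower number from compound 2 to compound 4 (0.02 log units; within the scatter): the same change on two cores in this assay, a 1.1-fold lower number (0.04 log units; within the scatter) from compound 1 to compound 3 and a 1.0-fold lower number (0.02 log units; within the scatter) from compound 2 to compound 4, 1.0-fold (0.02 log units) apart, within the scatter of two such steps. Among these compounds, the four compounds therefore form a consistent square in which each change carries from one core to the other, but every step lies within the scatter, so this agreement shows only that neither change has a detectable effect here, not that a real effect transfers between cores.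

The compounds shown leave open whether a group such as an amine, a carboxylic acid or a nitrile, in the place held by trifluoromethyl and hydroxy, would give a step beyond the scatter, and whether such a step would carry between these two cores as well. Also open, on these data alone, is whether a longer chain to the guanidine would move the number on either core, and whether any of these changes would behave alike on a core other than these two.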